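The compounds below may be only part of what the source reports. "The series", "measured", "known", "first", "only" and "open" are said of these compounds alone.

Measured set, in a functional assay on C8166 cells (Homo sapiens) for cytotoxicity, read by MTT assay; on this read-out higher numbers stand for lower toxicity in this test and lower numbers for higher toxicity in this test:
compound 1 `Cc1cc(S(N)(=O)=O)ccc1NC(=O)COc1ccc(Cl)cc1NC(=O)c1cccc([N+](=O)[O-])c1` gives 58800 nM
compound 2 `Cc1ccc(C(=O)Nc2cc(Cl)ccc2OCC(=O)Nc2ccc(S(N)(=O)=O)cc2C)c(C)c1` gives 47600 nM
compound 3 `Cc1cc(C)cc(C(=O)Nc2cc(Cl)ccc2OCC(=O)Nc2ccc(S(N)(=O)=O)cc2C)c1` gives 36500 nM

Compound 1 holds the highest of the three numbers, but the spread is small: a 1.2-fold lower number from compound 1 to compound 2 (0.09 log units; within the scatter) and a 1.6-fold lower number from compound 1 to compound 3 (0.21 log units; within the scatter), both inside the scatter, so the three are not separable on these data. Compound 4 `Cc1cc(S(N)(=O)=O)ccc1NC(=O)COc1ccc(Cl)cc1NC(=O)c1cc(Cl)cc(Cl)c1` differs from compound 1 at one place: 3,5-dichlorophenyl in place of 3-nitrophenyl on a carbonyl carbon. The two measured steps that bear on this are the replacements of 3-nitrophenyl on the carbonyl carbon starting from compound 1, a 1.2-fold lower number from compound 1 to compound 2 (0.09 log units; within the scatter) and a 1.6-fold lower number from compound 1 to compound 3 (0.21 log units; within the scatter); neither moved the number beyond the scatter. No step beyond the scatter is therefore expected in this assay for the change to 3,5-dichlorophenyl. The estimate for compound 4 is 42000 nM, with a range of 18000 nM to 100000 nM. This estimate means an expected step of a 1.4-fold lower number from compound 1 to compound 4 (0.15 log units; within the scatter), within the scatter.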

Compound 4, half-maximal cytotoxic concentration: 72400 nM
Estimate against measurement, compound 4: 1.7-fold (0.24 log units) below; measured number inside the range.
By their numbers in this assay, from the lowest: compounds 3, 2, 1 and 4 (each within the scatter of the next).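

In this assay, 3,5-dichlorophenyl on a carbonyl carbon gives a 1.2-fold higher number from compound 1 to compound 4 (0.09 log units; within the scatter), a 1.5-fold higher number from compound 2 to compound 4 (0.18 log units; within the scatter) and a 2.0-fold higher number from compound 3 to compound 4 (0.30 log units; within the scatter). Chlorine-bearing, nitro-bearing and methyl-bearing phenyl groups at this position therefore remain inseparable across compounds 1, 2, 3 and 4. Nothing available accounts for this flat picture.

Open, going by these compounds, is whether a phenyl ring carrying an amine or a carboxylic acid would produce a step beyond the scatter. Also open, on these data alone, is whether an open alkyl chain in place of the ring would do so.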